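A Stability Limit and a Ring-Free Replacement

The source may hold more compounds than are shown below. What is called first, only, known or untested is meant among the compounds shown, and "the series" means these compounds.

In an in vitro ADME assay on microsomes from liver (Homo sapiens) for metabolic stability (a lower number here means that the compound disappears faster, a higher number that the compound lasts longer), compound 1 `O=C1CN(c2ncccc2C(F)(F)F)CCN1S(=O)(=O)c1ccc(Cl)c(Cl)c1` gives 0.1 h and compound 2 `O=S(=O)(c1ccc(Cl)c(Cl)c1)N1CCN(c2ccccc2C(F)(F)F)CC1` gives 0.05 h as its reading, two values within the scatter of each other. Compound 3 `C[C@@H]1CN(c2ccc(F)cc2C(F)(F)F)CCN1S(=O)(=O)c1cccc(N2CCC(C(=O)O)C2)c1` gives > 0.5 h in this assay, and that reading is a limit of the assay and not a number. Compound 4 `C[C@@H]1CN(c2ccc(F)cc2C(F)(F)F)CCN1S(=O)(=O)c1cccc(OC(C)(C)C(=O)O)c1` carries 1-carboxy-1-methylethoxy in place of 3-carboxypyrrolidin-1-yl on an aromatic carbon and so loses the five-membered non-aromatic ring. Within the data shown here, no measured pair of compounds differs in one place only, so the size of this change has no direct precedent. A small downward step or none beyond the scatter is expected in this assay, with an at least 1.1-fold lower number from compound 3 to compound 4 (0.04 log units; that floor lies within the scatter) as the estimated move. This expectation rests on compound 3, whose > 0.5 h reading is a limit, and on the core that compound 4 keeps unchanged. For compound 4 the estimate is 0.45 h as the expected half-life, with an expected range from 0.2 h to 0.8 h in this measurement.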

Compound 4, half-life: > 0.5 h
Compound 4: no number, only a limit; the forecaster's own chance of this, stated with the estimate: 55%; middle value at least 1.1-fold (0.04 log units) away from the limit.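

The step from compound 3 to compound 4 cannot be read, because both readings are limits and not numbers in this assay: the limit of > 0.5 h in this assay, at which 2 of the 4 values shown sit.

The compounds shown leave open how far either half-life lies beyond that limit, and so whether 1-carboxy-1-methylethoxy and 3-carboxypyrrolidin-1-yl differ at all here.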